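From (pyridin-2-yl)methyl to ethyl at the assay limit

A few compounds are considered here, and "the series" means these few. Any claim that something is new, unique, unknown or untested is made for them only; others in the source may bear on it.

Measured in a functional assay on cells (Platelet, Homo sapiens) for inhibition; on this read-out higher numbers stand for weaker inhibition and lower numbers for stronger inhibition:
Compound 1 `CCOC(=O)c1ccc(-c2nn(Cc3cccc(Cl)c3)c3ccccc23)cc1`: > 10000 nM
Compound 2 `CCOC(=O)c1ccc(-c2nn(Cc3cccc(F)c3)c3ccccc23)cc1`: > 10000 nM
Compound 3 `CCOC(=O)c1ccc(-c2nn(Cc3ccccn3)c3ccccc23)cc1`: > 10000 nM

Compound 3 gives > 10000 nM, which is a limit and not a number. The same holds across the series, with the limit of > 10000 nM in this assay, at which 3 of the 3 values shown sit. Compound 4 `CCOC(=O)c1ccc(-c2nn(CC)c3ccccc23)cc1` differs from it by methyl in place of pyridin-2-yl on a saturated chain carbon bound to an aromatic nitrogen. This is methyl in place of pyridin-2-yl on a saturated chain carbon bound to an aromatic nitrogen, so that (pyridin-2-yl)methyl becomes ethyl.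

Two measured steps change this same place: a step that the two limits leave unreadable from compound 1 to compound 3 and a step that the two limits leave unreadable from compound 2 to compound 3. A third, a step that the two limits leave unreadable from compound 1 to compound 2, also gives no size. With no readable size among them, they suggest no direction, and no step beyond the scatter is expected in this assay. The expected step is a step that the limit leaves unreadable from compound 3 to compound 4. For compound 4 the estimated value is 12000 nM, within an expected range from 5000 nM to 30000 nM.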

Compound 4, half-maximal inhibitory concentration: > 10000 nM
Compound 4 was reported as a limit; the forecaster's own chance of this, stated with the estimate: 85%; the middle value is on the limit's open side.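

In this assay, for the compounds shown here, compound 4 gives > 10000 nM, which is a limit and not a number, so no step from compound 1, compound 2 or compound 3 to compound 4 can be read. The compounds shown leave open how strongly any of them inhibits and whether the group at this place matters, as the whole series stands at one limit: the limit of > 10000 nM in this assay, at which 4 of the 4 values shown sit.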